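The source may report more compounds than this note shows. Statements on the series, on what has been measured and on what is new or still open speak of the compounds shown alone.

In a functional assay on MV4-11 cells (Homo sapiens) for antiproliferative activity, read by luminescence and CellTiter-Glo, with a stated time of 72 h (on this read-out lower numbers stand for stronger inhibition and higher numbers for weaker inhibition), compound 1 (`CNc1cc(-c2ccc3cnn(Cc4ccc(F)cc4)c3c2)cn(C)c1=O`) gives 2390 nM and compound 2 (`CNc1cc(-c2ccc3cnn(Cc4ccc(C)cc4)c3c2)cn(C)c1=O`) gives 3280 nM, so compound 2 stands level with compound 1 within the scatter. Compound 3 (`CNc1cc(-c2ccc3cnn(Cc4cc(OC)cc(OC)c4)c3c2)cn(C)c1=O`) carries 3,5-dimethoxyphenyl in place of 4-methylphenyl on a saturated chain carbon bound to an aromatic nitrogen. Among the measured compounds shown here, the only measured step, a 1.4-fold higher number from compound 1 to compound 2 (0.14 log units; within the scatter), exchanges methyl for fluoro on an aromatic carbon and lies within the scatter. It bears only loosely on this larger change, so no step beyond the scatter is expected in this assay, though the uncertainty is wide. For compound 3 the estimate is 3000 nM, with an expected range of 1000 nM to 9000 nM, which means an expected step of a 1.1-fold lower number from compound 2 to compound 3 (0.04 log units; within the scatter).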

Compound 3, half-maximal inhibitory concentration: 190 nM
The estimate for compound 3 lay 16-fold (1.20 log units) above the measured number; measured number outside the range, below it.
By their numbers in this assay, from the lowest: compound 3; then compounds 1 and 2 (each within the scatter of the next).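

In this assay, the group on the saturated chain carbon bound to an aromatic nitrogen can move the read-out well beyond the scatter: 3,5-dimethoxyphenyl gives (a 17-fold lower number from compound 2 to compound 3 (1.24 log units; beyond the scatter)) against 4-methylphenyl and (a 13-fold lower number from compound 1 to compound 3 (1.10 log units; beyond the scatter)) against 4-fluorophenyl. The earlier exchange of methyl for fluoro had shown no such sensitivity here. Nothing measured accounts for this gain. From the compounds shown here alone, it remains open whether a single methoxy group would do the same, and how a hydroxyl, an amine or a longer ethoxy group would compare.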